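Replacing the quinolinyl arm with a fluoro-methylphenyl arm

The compounds below may be only part of what the source reports. "The series", "measured", "known", "first", "only" and "open" are said of these compounds alone.

Measured compounds:
- compound 1 `Cc1ccsc1/C=C(/SCc1ccc(F)cc1)C(=O)c1ccc(Br)cc1`, which in a functional assay on DU-145 cells (Homo sapiens) for inhibition, read by trypan blue exclusion, with a stated time of 96 h (a higher number here means a weaker inhibitor of growth, a lower number a stronger inhibitor of growth), gives 50000 nM
- compound 2 `COc1ccc(/C=C(/SCc2ccc(F)cc2)C(=O)c2ccc(Br)cc2)cc1O`, which in this assay gives 1000 nM
- compound 3 `O=C(/C(=C\c1ccc2ccccc2n1)SCc1ccc(F)cc1)c1ccc(Br)cc1`, which in this assay gives 25000 nM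

Compound 3 stands second highest of the three numbers. Its nearest neighbour is compound 1: the step of a 2.0-fold lower number from compound 1 to compound 3 (0.30 log units; within the scatter) lies within the scatter, so the two cannot be ranked. Its furthest neighbour is compound 2: the step of a 25-fold higher number from compound 2 to compound 3 (1.40 log units; beyond the scatter) is large.

Compound 4 `Cc1cc(F)ccc1/C=C(/SCc1ccc(F)cc1)C(=O)c1ccc(Br)cc1` is not yet measured. It differs from compound 3 in one place: 4-fluoro-2-methylphenyl in place of quinolin-2-yl on a double-bonded chain carbon bound to a double-bonded chain carbon.

All three measured steps change the same group at this same place. Within the data shown here, only the step of a 50-fold lower number from compound 1 to compound 2 (1.70 log units; beyond the scatter) brought a large gain, and that gain came with the 3-hydroxy-4-methoxyphenyl group; compound 4 has no hydroxyl and no acceptor on its new ring, so that gain is not expected here. Against this, the swap between two plain aromatic groups in a 2.0-fold lower number from compound 1 to compound 3 (0.30 log units; within the scatter) stayed within the scatter. A small step is therefore expected, a 1.7-fold lower number from compound 3 to compound 4 (0.22 log units; within the scatter), towards a slightly lower number. Compound 4 is estimated at 15000 nM, within 3000 nM to 60000 nM.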

Compound 4, concentration for 50% growth inhibition: 10000 nM
The estimate for compound 4 lay 1.5-fold (0.18 log units) above the measured number, and the stated range covers the measured number.
By their numbers in this assay, from the lowest: compound 2; then compound 4; then compounds 3 and 1 (each within the scatter of the next).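

Within this assay the 4-fluoro-2-methylphenyl group gives a 2.5-fold lower number from compound 3 to compound 4 (0.40 log units; beyond the scatter) and a 5.0-fold lower number from compound 1 to compound 4 (0.70 log units; beyond the scatter) and so shows that rings without a hydroxyl can still be told apart at this place, which the earlier swap of quinolin-2-yl for 3-methylthiophen-2-yl could not show. The 3-hydroxy-4-methoxyphenyl group of compound 2 still gives the lowest number, with a 10-fold higher number from compound 2 to compound 4 (1.00 log units; beyond the scatter) marking the gap, so the new ring closes only part of the distance to that group. Nothing at hand explains why these rings differ.

The compounds shown leave open whether the hydroxyl or the methoxy carries the lead of compound 2, and whether the fluorine or the methyl carries the gain of compound 4. They also leave open how a ring bearing an amine or a carboxylic acid would fare at this place.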